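The source may hold more compounds than are shown below. What is called first, only, known or untested is meant among the compounds shown, and "the series" means these compounds.

Working notes on the series in a functional assay on MCF7 cells (Homo sapiens) for cytotoxicity, read by MTT assay, with a stated time of 48 h; on this read-out higher numbers stand for weaker inhibition and lower numbers for stronger inhibition.

Three esters of the shared core have been taken through this assay. Compound 1 `CC(C)c1cccc(OC(=O)c2cn(-c3ccccc3)nc2-c2cccnc2)c1` gives 75500 nM in this assay. Compound 2 `COc1ccc(OC(=O)c2cn(-c3ccccc3)nc2-c2ccncc2)cc1` returns only a limit of the assay, > 100000 nM, and not a number. Among the compounds with values here, compound 3 `CC(C)c1cccc(OC(=O)c2cn(-c3ccccc3)nc2-c2ccncc2)c1` is recorded as "nd(insoluble)" (no result reported), so no number exists for it in this assay; the one further value shown for the set is the limit of > 100000 nM in this assay, at which 1 of the 3 values shown sits, and compound 3 therefore stands nowhere on the numbers, with no step to any measured compound to draw on.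

Compound 4 `Cc1ccc(C(C)C)c(OC(=O)c2cn(-c3ccccc3)nc2-c2ccncc2)c1` differs from compound 3 by 2-isopropyl-5-methylphenyl in place of 3-isopropylphenyl on an oxygen next to a carbonyl group. Within the data shown here, no measured step covers this change, and the two compounds that did give a reading, compound 1 and compound 2, both sit at the weak end of the assay. The expectation for compound 4 is therefore no step beyond the usual scatter from the weak readings already seen, with a fair chance that this assay again reports only a limit rather than a number. Compound 4 is estimated at 90000 nM in this assay, expected to lie between 30000 nM and 300000 nM.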

Compound 4, half-maximal inhibitory concentration: > 100000 nM
Compound 4: no number, only a limit; the forecaster's own chance of this, stated with the estimate: 50%; middle value at least 1.1-fold (0.04 log units) away from the limit.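

Compound 2 and compound 4 both return only a limit of the assay and not a number, so no step between them can be read in this assay: the limit of > 100000 nM in this assay, at which 2 of the 4 values shown sit.

The compounds shown leave open how 2-isopropyl-5-methylphenyl compares with 4-methoxyphenyl or 3-isopropylphenyl on the shared core in this assay.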